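This account rests on a few compounds, and the source may have more. Where it says the series, first, only, none or still open, it means among the compounds named here.

Working notes on the series. Compound 1 `CC(C)=CCN1CCN(CC(=O)C(O)(c2ccccc2)C2CCC2)CC1` is the reference point here. In a functional assay on ileum for antagonist activity at muscarinic acetylcholine receptor M3 (Cavia porcellus) (on this read-out lower numbers stand for stronger inhibition and higher numbers for weaker inhibition), compound 1 gives 22 nM, which is the only number shown for the set. Compound 2 `O=C(CN1CCN(C(c2ccccc2)c2ccccc2)CC1)C(O)(c1ccccc1)C1CCC1` in this assay returns only a limit, > 10000 nM, and no number. The set thus sits on the limit of > 10000 nM in this assay, at which 1 of the 2 values shown sits, for one of its two values.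

Compound 3 `CCOc1ccccc1N1CCN(CC(=O)C(O)(c2ccccc2)C2CCC2)CC1` is not yet measured in this assay. It differs from compound 1 in one place: 2-ethoxyphenyl in place of 3-methylbut-2-en-1-yl on an amine nitrogen in a ring. No measured step between two compounds of the series covers a change of this kind, so the size of the step cannot be read off the shown values. The expectation for this assay is a step going toward weaker inhibition, a 9.1-fold higher number from compound 1 to compound 3 (0.96 log units; beyond the scatter), going beyond the scatter but not reaching the limit. On that basis compound 3 is estimated at 200 nM, with a range from 40 nM to 2000 nM.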

Compound 3, antagonist equilibrium constant: > 10000 nM
Compound 3: only a limit was reported; the forecaster's own chance of this, stated with the estimate: 15%; at least 50-fold (1.69 log units) between middle value and limit.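

Placing 2-ethoxyphenyl on this amine nitrogen in a ring, in place of 3-methylbut-2-en-1-yl, gives an at least 450-fold higher number from compound 1 to compound 3 (2.65 log units; beyond the scatter) in this assay, so the response at this position depends strongly on the group it carries. Going by these compounds, compound 3 returns > 10000 nM, which is a limit and not a number, so the true size of the step stays unknown and could be larger than printed. Compound 2 carries another ring-bearing group on the same nitrogen and also gives only a limit, which leaves compound 1 as the only compound with a number and the two ring-bearing groups shown both at the limit: the limit of > 10000 nM in this assay, at which 2 of the 3 values shown sit.

The compounds shown leave open whether the step follows from the aromatic ring of 2-ethoxyphenyl, from its ethoxy group or from the loss of the 3-methylbut-2-en-1-yl chain itself; a plain phenyl or a benzyl group on that nitrogen would begin to separate these. Also open, on these data alone, is whether a saturated chain such as butyl keeps a measurable value in this assay, which would show how much the double bond of compound 1 matters.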